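Swapping iodo for trifluoromethoxy on the arylamino ring

The compounds below may be only part of what the source reports. "The series", "measured", "known", "first", "only" and "open" are said of these compounds alone.

Compound 3 `O=C(C1=C(Nc2ccc(I)cc2)C(=O)N(CCCn2ccnc2)C1c1ccc(Br)cc1)c1ccccc1` gives 24500 nM in a functional assay on A549 cells (Homo sapiens) for antiproliferative activity, read by MTT assay, with a stated time of 72 h (a higher number here means a weaker inhibitor, a lower number a stronger inhibitor), the highest of the three numbers shown. Compound 1 `CCCCCOC1=C(C(=O)c2ccccc2)C(c2ccc(Br)cc2)N(CCCn2ccnc2)C1=O` gives 7290 nM and compound 2 `CCCCOC1=C(C(=O)c2ccccc2)C(c2ccc(Br)cc2)N(CCCn2ccnc2)C1=O` gives 18500 nM. The gap a 1.3-fold higher number from compound 2 to compound 3 (0.12 log units; within the scatter) lies within the scatter, while a 3.4-fold higher number from compound 1 to compound 3 (0.53 log units; beyond the scatter) and a 2.5-fold higher number from compound 1 to compound 2 (0.40 log units; beyond the scatter) go beyond it. Compound 4 `O=C(C1=C(Nc2ccc(OC(F)(F)F)cc2)C(=O)N(CCCn2ccnc2)C1c1ccc(Br)cc1)c1ccccc1` differs from compound 3 by trifluoromethoxy in place of iodo on an aromatic carbon. None of the measured steps touches this ring, so nothing shown bears directly on the change, and the expectation is a step of a 1.2-fold lower number from compound 3 to compound 4 (0.09 log units; within the scatter), within the scatter. Compound 4 is therefore expected to give about 20000 nM, estimated between 7000 nM and 60000 nM.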

Compound 4, half-maximal inhibitory concentration: 20800 nM
The estimate for compound 4 lay 1.0-fold (0.02 log units) below the measured number; the range from low to high includes it.
By their numbers in this assay, from the lowest: compound 1; then compounds 2, 4 and 3 (each within the scatter of the next).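

In this assay, the first change shown on this aromatic ring gives a 1.2-fold lower number from compound 3 to compound 4 (0.07 log units; within the scatter), so swapping iodo for trifluoromethoxy here leaves the number within the scatter. On the double-bonded ring carbon, (4-(trifluoromethoxy)phenyl)amino gives a 1.1-fold higher number from compound 2 to compound 4 (0.05 log units; within the scatter) in place of butoxy, but a 2.9-fold higher number from compound 1 to compound 4 (0.46 log units; beyond the scatter) in place of pentyloxy. No measurement shown explains any of these steps. The compounds shown leave open whether an amine or a carboxylic acid on this aromatic ring would shift the number, and whether a chain longer than pentyloxy would lower it further.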